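Swapping a Thiophene for a Carboxyethyl Chain on the Hydrazide

The source may report more compounds than this note shows. Statements on the series, on what has been measured and on what is new or still open speak of the compounds shown alone.

In a functional assay on the whole organism (strain Wistar) for inhibition, with Rattus norvegicus as the target, read by paw edema, with stated times of 30 min and 3 h, at a dose of 20 mg/kg (on this read-out higher numbers stand for more inhibition at the one dose given (going by the name of the read-out) and lower numbers for less inhibition), compound 2 `CCOC(=O)C1=C(C)NC(C)=C(C(=O)OCC)C1c1ccc(OCC(=O)NNC(=O)c2cccs2)cc1` gives 61.1% and stands within the scatter of compound 1 `CCOC(=O)C1=C(C)NC(C)=C(C(=O)OCC)C1c1ccc(OCC(=O)Nc2nc3ccccc3s2)cc1`, which gives 65.9%; the step between them was a number 4.8 percentage points lower from compound 1 to compound 2 (within the scatter). Compound 3 `CCOC(=O)C1=C(C)NC(C)=C(C(=O)OCC)C1c1ccc(OCC(=O)NNC(=O)CCC(=O)O)cc1` differs from compound 2 by 2-carboxyethyl in place of thiophen-2-yl on a carbonyl carbon. Going by the values given here, only that one measured step bears on this change: it also reworked the group on the amide-type nitrogen and stayed within the scatter. The change to compound 3 is therefore expected to give a number 3.1 percentage points lower from compound 2 to compound 3 (within the scatter), nothing beyond the scatter. Compound 3 is estimated at 58%, within 44% to 72%.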

Compound 3, a percentage reported as inhibition, in the whole organism at one dose (the size of the read-out at that dose, not a potency): 56.9%
Compound 3: the middle estimate sits 1.1 percentage points above what was measured; the range from low to high includes it.
By their numbers in this assay, from the lowest: compounds 3, 2 and 1 (each within the scatter of the next).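

In this assay, the open 2-carboxyethyl chain on the carbonyl carbon, in place of the thiophen-2-yl ring, gives a number 4.2 percentage points lower from compound 2 to compound 3 (within the scatter) and so shows that this position holds either a ring or an open chain without a step beyond the scatter. Replacing the 1,3-benzothiazol-2-yl group on the amide-type nitrogen with the whole ((2-carboxyethyl)carbonyl)amino group gives a number 9 percentage points lower from compound 1 to compound 3 (within the scatter) and also stays within the scatter. No measurement here explains why these different groups read alike. As far as these compounds go, how an aminoethyl chain or a longer chain ending in a carboxylic acid would read on this carbonyl carbon remains open.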